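Series near the growth-inhibition limit: compound 1 to compound 4

The source may hold more compounds than are shown below. What is called first, only, known or untested is meant among the compounds shown, and "the series" means these compounds.

Among the measured compounds shown here, in a functional assay on U-373MG ATCC cells for inhibition, with U373 MG (Homo sapiens) as the target, read by MTT assay, with a stated time of 7 days (on this read-out higher numbers stand for weaker inhibition of growth and lower numbers for stronger inhibition of growth), compound 1 `C[Si](C)(C)Cn1nnc2c(C(N)=O)ncn2c1=O` gives 45600 nM, the only number available. Compound 2 `COc1ccc(Cn2nnc3c(C(N)=O)ncn3c2=O)cc1` reads > 50000 nM, which is a limit and not a number. Compound 3 `COc1ccc(Cn2nnc3c(C(N)=O)ncn3c2=O)c(OC)c1` reads > 50000 nM, likewise a limit. The series therefore sits largely at the limit of > 50000 nM in this assay, at which 2 of the 3 values shown sit. For the measured compounds named here, the only step between measured compounds is a step that the two limits leave unreadable from compound 2 to compound 3, so it offers no size to carry forward.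

Compound 4 `NC(=O)c1ncn2c(=O)n(Cc3ccsc3)nnc12` differs from compound 1 as follows: a group of 5 heavy atoms (4 carbon, 1 sulfur; one five-membered aromatic ring with 1 hetero atom) in place of a group of 4 heavy atoms (3 carbon, 1 silicon; no ring), on a saturated chain carbon bound to an aromatic nitrogen. Going by the values given here, no measured step covers this exchange, so compound 1 at 45600 nM remains the sole numerical anchor. With no readable step to apply, no shift beyond the usual scatter is expected in this assay, and no direction is assigned. The estimated step is a 1.1-fold higher number from compound 1 to compound 4 (0.04 log units; within the scatter). A report of only a limit is also quite possible for this compound. For compound 4 the estimated value is 50000 nM, with an expected range of 28000 nM to 90000 nM.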

Compound 4, concentration for 50% growth inhibition: > 50000 nM
Compound 4 ended at the assay's limit; the forecaster's own chance of this, stated with the estimate: 55%; the middle value sits exactly at the limit.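

In this assay, thiophen-3-yl in place of the group of 3 carbon and 1 silicon, on a saturated chain carbon bound to an aromatic nitrogen, gives an at least 1.0-fold higher number from compound 1 to compound 4 (0.04 log units; that floor lies within the scatter). Compound 4 reports only a limit, not a number, so this floor is all that can be read of the exchange, and a five-membered aromatic ring with 1 hetero atom at this place does not yield a measurable value. The series gathers further at a single reading: the limit of > 50000 nM in this assay, at which 3 of the 4 values shown sit.

Among the compounds shown here, the step between the methoxy compounds cannot be read, and compound 1 remains the only compound with a number to compare against. From the compounds shown here alone, whether an amine, a carboxylic acid or a longer chain at this place would give a value clearly separated from the limit stays open.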